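Trimming a methoxy from compound 2

This account rests on a few compounds, and the source may have more. Where it says the series, first, only, none or still open, it means among the compounds named here.

Compound 2 `COc1ccc(C(=O)/C=C/c2cc(-c3cc(OC)c(OC)c(OC)c3)n[nH]2)cc1OC` is the lower of the two numbers in a functional assay on 786-0 cells (Homo sapiens) for cytotoxicity, read by sulforhodamine B assay, with a stated time of 48 h, tested at 1 uM (on this read-out higher numbers stand for a weaker effect at the one concentration tested and lower numbers for a stronger effect), where compound 2 gives 74%; compound 1 `COc1cc(-c2cc(/C=C/C(=O)c3ccc(Cl)c(Cl)c3)[nH]n2)cc(OC)c1OC` gives 91% in this assay. Going by the values given here, the one measured step, a number 17 percentage points lower from compound 1 to compound 2 (beyond the scatter), concerns the same ring but a different exchange of groups. Among the compounds with values here, compound 3 `COc1ccc(C(=O)/C=C/c2cc(-c3cc(OC)c(OC)c(OC)c3)n[nH]2)cc1` differs from compound 2 by hydrogen in place of methoxy on an aromatic carbon, a change on which no measured step bears. Compound 3 is expected to show a number 6 percentage points higher from compound 2 to compound 3 (within the scatter) in this assay, a step that may well stay within the scatter. For compound 3 the estimate in this assay is 80%, ranging from 62% to 98%.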

Compound 3, a percentage reported as activity, at one concentration (the size of the read-out at that concentration, not a potency): 94%
Beside the measured number, compound 3's estimate is 14 percentage points below it; the measured number falls inside the stated range.
By their numbers in this assay, from the lowest: compound 2; then compounds 1 and 3 (each within the scatter of the next).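

In this assay, hydrogen in place of this methoxy gives a number 20 percentage points higher from compound 2 to compound 3 (beyond the scatter), so the position on the 3,4-dimethoxyphenyl ring is not indifferent to the change. Going by these compounds alone, the step of a number 3 percentage points higher from compound 1 to compound 3 (within the scatter) puts the 4-methoxyphenyl and 3,4-dichlorophenyl compounds level, leaving 3,4-dimethoxyphenyl as the only one of the three groups set apart by its number. Nothing available explains why this methoxy matters.

Open, as far as these compounds go, is whether a hydroxyl or an amine at this position would hold the number of compound 2. Also open, from the compounds shown here alone, is whether a longer chain such as ethoxy would do so.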